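Trimethoxyphenyl for chlorophenyl on the shared core

The compounds below may be only part of what the source reports. "The series", "measured", "known", "first", "only" and "open" are said of these compounds alone.

Of the compounds shown here, two have been measured in a functional assay on SK-MEL-5 cells (Homo sapiens) for inhibition; a lower number here means a stronger inhibitor of growth, a higher number a weaker inhibitor of growth. Compound 1 `COc1cc(/C=C/C(=O)c2cccc(-n3cc(-c4ccc(Cl)cc4)[nH]c3=O)c2)cc(OC)c1OC` gives 8700 nM and stands as the higher of the two numbers. Within the data shown here, compound 2 `O=C(/C=C/c1cccc(O)c1)c1cccc(-n2cc(-c3ccc(Cl)cc3)[nH]c2=O)c1` gives 1530 nM; the two compounds differ at more than one place, so no single-point step is drawn between them, and the values show only that compound 2 sits at the lower number, well apart from compound 1.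

Compound 3 `COc1cc(/C=C/C(=O)c2cccc(-n3cc(-c4cc(OC)c(OC)c(OC)c4)[nH]c3=O)c2)cc(OC)c1OC` has not been measured. Relative to compound 1 the change is 3,4,5-trimethoxyphenyl in place of 4-chlorophenyl on an aromatic carbon on an aromatic carbon of the five-membered aromatic ring with 2 nitrogen, next to the ring nitrogen; the remainder of the molecule is unchanged. Among the measured compounds shown here, no measured pair isolates this exchange, so no measured step bears on it directly.

The step from compound 1 to compound 3 is expected to stay within the usual scatter, with no clear direction, as a 1.1-fold higher number from compound 1 to compound 3 (0.06 log units; within the scatter). Compound 3 is therefore expected to give about 10000 nM in this assay, with a plausible range from 3000 nM to 35000 nM.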

Compound 3, concentration for 50% growth inhibition: 2760 nM
Beside the measured number, compound 3's estimate is 3.6-fold (0.56 log units) above it; measured number below the stated range.
By their numbers in this assay, from the lowest: compounds 2 and 3 (each within the scatter of the next); then compound 1.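

In this assay the position on the aromatic carbon of the five-membered aromatic ring gives its first readable single-place result: with 3,4,5-trimethoxyphenyl in place of 4-chlorophenyl, the step is a 3.2-fold lower number from compound 1 to compound 3 (0.50 log units; beyond the scatter), a modest one beyond the scatter. The 4-chlorophenyl is therefore not needed for growth inhibition on the background of compound 1, and the position accepts an entering group that has more heavy atoms and carries hydrogen-bond acceptors, where the leaving group has none. No measurement at hand accounts for the direction of this step.

A single exchange cannot separate the loss of chlorine from the gain of the methoxy groups, and a plain phenyl, a 4-methoxyphenyl or a 4-aminophenyl at this position would begin to pull these apart. As far as these compounds go, it also remains open whether the same exchange carries over to the 3-hydroxyphenyl end of compound 2, or whether the step belongs only to the trimethoxyphenyl background shared by compound 1 and compound 3.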